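The source may report more compounds than this note shows. Statements on the series, on what has been measured and on what is new or still open speak of the compounds shown alone.

Measured so far:
- compound 1 `Cc1cc(C)cc(-c2c(O)nc3cc(Cl)c(NC(=O)c4cnccn4)cc3c2OCCC2CCCCN2)c1` — 1.8 nM in a functional assay on cells (Pituitary gland cell) for antagonist activity at Gonadotropin-releasing hormone receptor (Rattus norvegicus); a higher number here means a weaker inhibitor, a lower number a stronger inhibitor
- compound 2 `O=C(Nc1cc2c(OCCC3CCCCN3)c(-c3ccc4ccccc4c3)c(O)nc2cc1Cl)NC1CC1` — 68 nM in this assay

Compound 1 holds the lowest of the two numbers in this assay. For the measured compounds named here, the only other measured compound, compound 2, gives the higher number, and the gap between the two lies beyond the scatter. Going by the values given here, the two structures differ in more than one place, so no single step between them can be read; their values show only that compound 1 is the stronger of the pair.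

Compound 3 `Cc1cc(C)cc(-c2c(O)nc3cc(Cl)c(NC(=O)Nc4ncccn4)cc3c2OCCC2CCCCN2)c1` is not yet measured. It differs from compound 1 in one place: (pyrimidin-2-yl)amino in place of pyrazin-2-yl on a carbonyl carbon. Among the compounds with values here, no measured pair isolates this change. The step from compound 1 to compound 3 is therefore expected to be small, and it is estimated to go toward a slightly higher number, a 2.2-fold higher number from compound 1 to compound 3 (0.35 log units; beyond the scatter), though a result within the scatter is also possible. Compound 3 is expected to give about 4 nM in this assay, with a range of 1 nM to 20 nM.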

Compound 3, half-maximal inhibitory concentration: 6 nM
Beside the measured number, compound 3's estimate is 1.5-fold (0.18 log units) below it; measured number inside the range.
By their numbers in this assay, from the lowest: compound 1; then compound 3; then compound 2.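

In this assay, for the compounds shown here, this is the first step that can be read in one place: a 3.3-fold higher number from compound 1 to compound 3 (0.52 log units; beyond the scatter) is modest but beyond the scatter, so the group on this carbonyl carbon does register in the read-out. The change from (pyrazin-2-yl)carbonyl to (pyrimidin-2-yl)carbamoyl alters the ring and inserts an amino link with one hydrogen-bond donor, and with both changes in place compound 3 still gives 6 nM in this assay. No measurement bears on why the number rises, so the step stands without an explanation.

Going by these compounds alone, the single step does not separate the ring exchange from the added amino link, and (pyrimidin-2-yl)carbonyl or (pyrazin-2-yl)amino on the same carbonyl carbon would divide the two contributions. On these data alone, whether the ring nitrogens matter at all also stays open, and phenylamino or (pyridin-2-yl)amino in this place would address that question.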